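The compounds below may be only part of what the source reports. "The series", "measured", "known", "first", "only" and "open" are said of these compounds alone.

In a functional assay on HL-60 cells (Homo sapiens) for inhibition, read by MTT assay, with a stated time of 72 h (on this read-out higher numbers stand for weaker inhibition and lower numbers for stronger inhibition), compound 1 (`COc1cc(OC)cc(N2CCN(C(=O)c3onc(C)c3-c3ccccc3F)CC2)c1`) gives 165 nM and compound 2 (`COc1cc(OC)cc(N2CCN(C(=O)c3onc(C)c3-c3ccc(F)cc3)CC2)c1`) gives 475 nM, so compound 2 holds the higher of the two numbers. Next is compound 3 (`COc1cc(OC)cc(N2CCN(C(=O)c3onc(C)c3-c3ccc(-c4ccco4)cc3)CC2)c1`), which carries furan-2-yl in place of fluoro on an aromatic carbon of compound 2, para to a large group: furan-2-yl in place of fluoro on an aromatic carbon. For the measured compounds named here, the only measured step that bears on this is a 2.9-fold higher number from compound 1 to compound 2 (0.46 log units; beyond the scatter). Going by the values given here, it is modest and concerns only the placing of fluoro, and no measured compound carries furan-2-yl. On these data alone, the data therefore favour no direction, and a change of about that modest size either way remains open. The step expected here is a 1.1-fold lower number from compound 2 to compound 3 (0.02 log units; within the scatter), with wide uncertainty. For compound 3 the estimated value is 450 nM, with an expected range from 130 nM to 1500 nM.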

Compound 3, half-maximal inhibitory concentration: 191 nM
Estimate against measurement, compound 3: 2.4-fold (0.37 log units) above; low and high end bracket the measured number.
By their numbers in this assay, from the lowest: compounds 1 and 3 (each within the scatter of the next); then compound 2.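

At the aromatic carbon para to a large group, furan-2-yl in place of fluoro gives a 2.5-fold lower number from compound 2 to compound 3 (0.40 log units; beyond the scatter) in this assay, so this position accepts a five-membered aromatic ring with no rise in the number. Comparing 4-(furan-2-yl)phenyl with 2-fluorophenyl gives a 1.2-fold higher number from compound 1 to compound 3 (0.06 log units; within the scatter), which leaves these two compounds indistinguishable on this read-out. Nothing available explains the change from fluoro to furan-2-yl.

On these data alone, it remains open whether the lower number is particular to furan-2-yl or would also come with a thiophene, a phenyl ring or a primary amine on this carbon. Also open, as far as these compounds go, is what a fluoro added elsewhere on the same six-membered ring of compound 3 would do to the number.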